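The source may hold more compounds than are shown below. What is called first, only, known or untested is meant among the compounds shown, and "the series" means these compounds.

In a functional assay for inhibition, with Homo sapiens as the target (a lower number here means a stronger inhibitor, a higher number a weaker inhibitor), three compounds have been measured:
compound 1 `CCCc1nc(C)c2cnnc(O)n12` gives 56800 nM;
compound 2 `CCCc1nnc(O)n2c(CCC)nc(C)c12` gives 16000 nM;
compound 3 `CCCc1nc(C)c2c(-c3ccccc3)nnc(O)n12` gives only a limit of the assay, > 48000 nM.

Compound 3 thus sits at the limit of > 48000 nM in this assay, at which 1 of the 3 values shown sits, the only one of the three that does. Compound 4 `CCCc1nc(C)c2c(C3CC3)nnc(O)n12` differs from it by cyclopropyl in place of phenyl on an aromatic carbon. For the measured compounds named here, two measured steps bear on this: an at least 3.0-fold higher number from compound 2 to compound 3 (0.47 log units; beyond the scatter), and a 3.6-fold lower number from compound 1 to compound 2 (0.55 log units; beyond the scatter); the step that the limit leaves unreadable from compound 1 to compound 3 cannot be read. Since the entering cyclopropyl has three heavy atoms, as propyl does, compound 4 is expected to fall back toward compound 2, giving an at least 1.6-fold lower number from compound 3 to compound 4 (0.20 log units; that floor lies within the scatter) in this assay . The estimate for compound 4 is 30000 nM, within 12000 nM to 90000 nM.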

Compound 4, half-maximal inhibitory concentration: > 48000 nM
Compound 4 ended at the assay's limit (the forecaster's own chance of this, stated with the estimate: 30%); at least 1.6-fold (0.20 log units) between middle value and limit.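

In this assay, cyclopropyl on this aromatic carbon, para to a hydroxy group, does not match propyl at the same place: an at least 3.0-fold higher number from compound 2 to compound 4 (0.47 log units; beyond the scatter). So among the groups shown here, only propyl gives a readable value, and the ring of cyclopropyl does not behave like the chain. Compound 4 joins compound 3 at the same limit of the assay: the limit of > 48000 nM in this assay, at which 2 of the 4 values shown sit.

As far as these compounds go, the steps from compound 3 and from compound 1 to compound 4 cannot be read, and how far past the limit either compound lies stays open. Also open, from the compounds shown here alone, is whether a longer chain, an amine or a methoxy group here would give a readable value.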